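A Second Bromo on Compound 3

The source may report more compounds than this note shows. Statements on the series, on what has been measured and on what is new or still open speak of the compounds shown alone.

In a functional assay on Huh-5-2 cells (Homo sapiens) for cytotoxicity, read by microscopy (on this read-out lower numbers stand for higher toxicity in this test and higher numbers for lower toxicity in this test), compound 1 (`CC(=O)OC[C@H]1O[C@@H](n2c(SCc3cc4cc(F)ccc4oc3=O)nc3cncnc32)[C@H](OC(C)=O)[C@@H]1OC(C)=O`) gives 7600 nM while compound 2 (`CC(=O)OC[C@H]1O[C@@H](n2c(SCc3cc4cc(Cl)ccc4oc3=O)nc3cncnc32)[C@H](OC(C)=O)[C@@H]1OC(C)=O`) gives 7500 nM and compound 3 (`CC(=O)OC[C@H]1O[C@@H](n2c(SCc3cc4cc(Br)ccc4oc3=O)nc3cncnc32)[C@H](OC(C)=O)[C@@H]1OC(C)=O`) gives 6700 nM on the same read-out. Compound 3 therefore stands level with the other two, all three lying within the scatter of one another.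

The change to compound 4 (`CC(=O)OC[C@H]1O[C@@H](n2c(SCc3cc4cc(Br)cc(Br)c4oc3=O)nc3cncnc32)[C@H](OC(C)=O)[C@@H]1OC(C)=O`) is bromo in place of hydrogen on an aromatic carbon, ortho to a fused ring and meta to a bromo group. The measured steps that bear on it only exchange one halogen for another. Thus a 1.0-fold lower number from compound 1 to compound 2 (0.01 log units; within the scatter) and a 1.1-fold lower number from compound 2 to compound 3 (0.05 log units; within the scatter) and a 1.1-fold lower number from compound 1 to compound 3 (0.05 log units; within the scatter) all stay within the scatter. None of them adds a halogen at a new place, so the evidence is indirect. No step beyond the scatter is expected in this assay and no direction is favoured. The expected step is a 1.1-fold lower number from compound 3 to compound 4 (0.05 log units; within the scatter) by this estimate. For compound 4 the estimated value is 6000 nM with an expected range from 3000 nM to 11000 nM on this read-out.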

Compound 4, half-maximal cytotoxic concentration: 6000 nM
Estimate against measurement, compound 4: no gap at the digits printed; the measured number falls inside the stated range.
By their numbers in this assay, from the lowest: compounds 4, 3, 2 and 1 (each within the scatter of the next).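

Among the compounds shown here, compound 4 is the first compound here in which a halogen enters in place of hydrogen rather than replacing another halogen, and in this assay this change gives a 1.1-fold lower number from compound 3 to compound 4 (0.05 log units; within the scatter) and so stays within the scatter. A bromo on this aromatic carbon, ortho to a fused ring and meta to a bromo group, therefore leaves the number level with that of compound 3, just as the earlier exchanges among fluoro, chloro and bromo left their numbers level. No measurement shown here offers an explanation for this result.

Whether this carbon would respond in the same way to an amine or a carboxylic acid remains open on the compounds shown. As far as these compounds go, it is equally open whether a longer chain at this place would carry the number beyond the scatter.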